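Cyclopropyl for 4-methylphenyl: working notes on compound 4

The compounds below may be only part of what the source reports. "The series", "measured", "known", "first", "only" and "open" are said of these compounds alone.

Measured so far in an ADME assay on HepG2 cells (Homo sapiens) for cytotoxicity, read by MTT assay, with a stated time of 24 h (a higher number here means that more compound is tolerated, a lower number that less compound is tolerated), are these compounds:
compound 1 `CC1Cn2cc([N+](=O)[O-])nc2O1` gives > 500000 nM (a limit)
compound 2 `CC1Cn2c(nc([N+](=O)[O-])c2Br)O1` gives 20100 nM (a number)
compound 3 `Cc1ccc(C#Cc2c([N+](=O)[O-])nc3n2CC(C)O3)cc1` gives 4440 nM (a number)

Compound 3 at 4440 nM holds the lowest number of the series, and compound 2 at 20100 nM stands higher, a gap beyond the scatter. Compound 4 `CC1Cn2c(nc([N+](=O)[O-])c2C#CC2CC2)O1` is next, and cyclopropyl in place of 4-methylphenyl on a triple-bonded carbon is its whole difference from compound 3.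

Within the data shown here, the only measured step is an at least 24-fold lower number from compound 1 to compound 2 (1.39 log units; beyond the scatter) and it is large. the limit of > 500000 nM in this assay, at which 1 of the 3 values shown sits, marks the start of that step as a limit. That step touches no group on a triple-bonded carbon, so it bears only loosely here and shows just that one change can move the number far.

A moderate rise is expected, and a 2.3-fold higher number from compound 3 to compound 4 (0.35 log units; beyond the scatter) is the estimated step in this assay towards more compound tolerated. Compound 2 at 20100 nM is the nearest measured number above, and the expectation stays close to it. For compound 4 10000 nM is the estimate, with 3000 nM to 35000 nM as the expected range.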

Compound 4, half-maximal cytotoxic concentration: 14800 nM
Beside the measured number, compound 4's estimate is 1.5-fold (0.17 log units) below it; the measured number falls inside the stated range.
By their numbers in this assay, from the lowest: compound 3; then compounds 4 and 2 (each within the scatter of the next). At a limit, above all of these: compound 1.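

At the triple-bonded carbon, the group carried matters in this assay: a 3.3-fold higher number from compound 3 to compound 4 (0.52 log units; beyond the scatter), with cyclopropyl in place of 4-methylphenyl. Bromo and 2-cyclopropylethynyl on the aromatic carbon cannot be told apart here, as a 1.4-fold lower number from compound 2 to compound 4 (0.13 log units; within the scatter) shows, so a triple-bonded substituent as such does not set the number apart from bromo. With hydrogen on that aromatic carbon the start is a limit and not a number, so an at least 33-fold lower number from compound 1 to compound 4 (1.52 log units; beyond the scatter) gives only a bound: the limit of > 500000 nM in this assay, at which 1 of the 4 values shown sits.

With only cyclopropyl and 4-methylphenyl at the triple-bonded carbon, the effect of ring size cannot be separated from that of an aromatic ring. From the compounds shown here alone, how an unsubstituted phenyl, an amine, a carboxylic acid or a longer alkyl chain would stand at that place remains open.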